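The compounds below may be only part of what the source reports. "The series", "measured", "known", "first", "only" and "open" are said of these compounds alone.

Among the compounds with values here, in a functional assay (blood) for inhibition, with Homo sapiens as the target (a higher number here means a weaker inhibitor, a lower number a stronger inhibitor), compound 2 `CO/N=C(\C)c1ccc(Sc2cc(F)cc(C3CCOCC3)c2)cc1` gives 110 nM, the higher of the two numbers known here. Compound 3 `COC1(c2cc(F)cc(Sc3ccc4c(c3)CC/C4=N\OCC#N)c2)CCOCC1` gives 30 nM, a gap beyond the usual scatter. Compound 1 `OC1O[C@H](CO/N=C2\CCc3cc(Sc4cc(F)cc(C5CCOCC5)c4)ccc32)[C@H](O)[C@H](O)[C@H]1O` reaches only a limit of this assay, namely > 2500 nM (the limit of > 2500 nM in this assay, at which 1 of the 3 values shown sits). Compound 4 `C/C(=N\OCCSc1nnc(C)s1)c1ccc(Sc2cc(F)cc(C3CCOCC3)c2)cc1` differs from compound 2 by ((5-methyl-1,3,4-thiadiazol-2-yl)sulfanyl)methyl in place of hydrogen on a saturated chain carbon bound to an oxygen. Within the data shown here, no measured pair shows this change alone; compound 3 and compound 1 each differ from compound 2 in more than one place, and their results point in opposite directions. A step of modest size is therefore expected in this assay, with no firm direction, as a 1.1-fold lower number from compound 2 to compound 4 (0.04 log units; within the scatter). Compound 4 is estimated at 100 nM, with a range from 30 nM to 400 nM.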

Compound 4, half-maximal inhibitory concentration: 230 nM
Beside the measured number, compound 4's estimate is 2.3-fold (0.36 log units) below it, within the range that was stated.
By their numbers in this assay, from the lowest: compound 3; then compound 2; then compound 4. At a limit, above all of these: compound 1.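

In this assay, within the data shown here, the one single change available here reads as a 2.1-fold higher number from compound 2 to compound 4 (0.32 log units; beyond the scatter), so the saturated chain carbon bound to an oxygen carries ((5-methyl-1,3,4-thiadiazol-2-yl)sulfanyl)methyl, with its five-membered aromatic ring, at a modest cost. Nothing given here accounts for this step. As far as these compounds go, whether the cost comes from the added chain or from the ring stays open. A plain 2-hydroxyethyl chain, or a 2-aminoethyl chain in the same place, would separate the two.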